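The source may report more compounds than this note shows. Statements on the series, on what has been measured and on what is new or still open speak of the compounds shown alone.

Compound 1 `COC(=O)N[C@H](C(=O)N1C[C@@H](C)C[C@H]1c1nc2cc(/C=C/c3ccc(-c4cc5[nH]c([C@@H]6C[C@H](C)CN6C(=O)[C@@H](NC(=O)OC)C(C)C)nc5s4)cc3)ccc2[nH]1)C(C)C` gives > 20000 nM in an ADME assay on HuhET cells (Homo sapiens) for cytotoxicity, read by thymidine incorporation (a lower number here means that less compound is tolerated, a higher number that more compound is tolerated), which is a limit of that assay and not a number; this is the limit of > 20000 nM in this assay, at which 1 of the 3 values shown sits. Compound 2 `COC(=O)N[C@H](C(=O)N1C[C@@H](C)C[C@H]1c1ncc(-c2csc3ccc(-c4ccc(-c5cc6[nH]c([C@@H]7C[C@H](C)CN7C(=O)[C@@H](NC(=O)OC)C(C)C)nc6s5)cc4)cc23)[nH]1)C(C)C` gives 16400 nM in this assay. Compound 3 `COC(=O)N[C@H](C(=O)N1C[C@@H](C)C[C@H]1c1ncc(-c2ccc(-c3ccc(-c4cc5[nH]c([C@@H]6C[C@H](C)CN6C(=O)[C@@H](NC(=O)OC)C(C)C)nc5s4)cc3)c(F)c2)[nH]1)C(C)C` gives 3100 nM, the lowest of the two numbers shown, with compound 2 sitting at a higher number beyond the scatter. Compound 4 `COC(=O)N[C@H](C(=O)N1C[C@@H](C)C[C@H]1c1ncc(-c2ccc(-c3ccc(-c4cc5[nH]c([C@@H]6C[C@H](C)CN6C(=O)[C@@H](NC(=O)OC)C(C)C)nc5s4)cc3)c(C)c2)[nH]1)C(C)C` differs from compound 3 by methyl in place of fluoro on an aromatic carbon. Among the measured compounds shown here, no step between two measured compounds shows how such a swap moves this assay, so nothing beyond the scatter is expected, in either direction. Compound 4 is therefore estimated at 4000 nM, between 1500 nM and 12000 nM. That estimate corresponds to an expected step of a 1.3-fold higher number from compound 3 to compound 4 (0.11 log units; within the scatter).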

Compound 4, half-maximal cytotoxic concentration: > 20000 nM
Compound 4: no number, only a limit (the forecaster's own chance of this, stated with the estimate: 10%); middle value at least 5.0-fold (0.69 log units) from the limit.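

On this aromatic carbon, ortho to a large group and meta to a large group, methyl in place of fluoro gives the first single-place comparison, and in this assay it produces an at least 6.4-fold higher number from compound 3 to compound 4 (0.80 log units; beyond the scatter). Exchanging one heavy atom here is therefore enough to move the read-out beyond the scatter, towards more compound tolerated. The reading for compound 4 is a limit of the assay and not a number: the limit of > 20000 nM in this assay, at which 2 of the 4 values shown sit.

The compounds shown leave open the true size of this step. They also leave open whether chloro, methoxy or an amine on this carbon would move the read-out the same way.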